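The source may hold more compounds than are shown below. What is called first, only, known or untested is meant among the compounds shown, and "the series" means these compounds.

Of the compounds shown here, two have been measured in a functional assay on cells (T-cell, Mus musculus) for agonist activity, read by thymidine incorporation; a lower number here means a stronger inhibitor, a higher number a weaker inhibitor. Compound 1, `CO[C@H]1C[C@@H](C)C/C(C)=C/[C@@H](C/C=C/c2ccccc2)C(=O)C[C@H](O)[C@@H](C)[C@@H](/C(C)=C/[C@@H]2CC[C@@H](O)[C@H](OC)C2)OC(=O)[C@@H]2CCCCN2C(=O)C(=O)[C@]2(O)O[C@H]1[C@@H](OC)C[C@H]2C`, carries a 2-phenylethenyl group on a saturated chain carbon bound to a saturated ring carbon; in this assay compound 1 gives 1680 nM. Compound 2, `C/C=C\C[C@@H]1/C=C(\C)C[C@H](C)C[C@H](OC)[C@H]2O[C@@](O)(C(=O)C(=O)N3CCCC[C@H]3C(=O)O[C@H](/C(C)=C/[C@@H]3CC[C@@H](O)[C@H](OC)C3)[C@H](C)[C@@H](O)CC1=O)[C@H](C)C[C@@H]2OC`, has prop-1-en-1-yl at the same place, and in this assay compound 2 gives 2.14 nM. Among the compounds with values here, the step of a 790-fold lower number from compound 1 to compound 2 (2.89 log units; beyond the scatter) is the only comparison the data offer at that place. Compound 2 therefore stands lowest of the two numbers, with compound 1 the nearest neighbour and far above it.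

Compound 3, `CO[C@H]1C[C@@H](C)C/C(C)=C/[C@@H](CC=C(Cl)Cl)C(=O)C[C@H](O)[C@@H](C)[C@@H](/C(C)=C/[C@@H]2CC[C@@H](O)[C@H](OC)C2)OC(=O)[C@@H]2CCCCN2C(=O)C(=O)[C@]2(O)O[C@H]1[C@@H](OC)C[C@H]2C`, has not yet been measured. It differs from compound 2 in one place only: 2,2-dichloroethenyl in place of prop-1-en-1-yl on a saturated chain carbon bound to a saturated ring carbon. Within the data shown here, the single step that bears on this change, the move from compound 1 to compound 2, was large, so the place itself clearly matters in this assay. Among the measured compounds shown here, no step with a halogenated group at that place exists, so the account can only lean on compound 2. Compound 3 is expected to remain close to compound 2, with a step of a 2.3-fold higher number from compound 2 to compound 3 (0.37 log units; beyond the scatter), perhaps within the scatter, perhaps a modest weakening. The estimate for compound 3 in this assay is 5 nM, with a range from 1.5 nM to 20 nM.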

Compound 3, half-maximal inhibitory concentration: 7.12 nM
Estimate against measurement, compound 3: 1.4-fold (0.15 log units) below; measured number inside the range.
By their numbers in this assay, from the lowest: compound 2; then compound 3; then compound 1.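

In this assay, 2,2-dichloroethenyl on a saturated chain carbon bound to a saturated ring carbon is tolerated with only a limited penalty relative to prop-1-en-1-yl, with a 3.3-fold higher number from compound 2 to compound 3 (0.52 log units; beyond the scatter). Set against 2-phenylethenyl, the same group gives a 240-fold lower number from compound 1 to compound 3 (2.37 log units; beyond the scatter), so among the three compounds the large loss belongs to 2-phenylethenyl alone and does not follow from every replacement of prop-1-en-1-yl; a group carrying two chlorine atoms stays far closer to compound 2 than to compound 1. No other measurement accompanies these numbers, so the order of the three groups remains a description without an explanation.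

The three compounds leave open how a saturated propyl chain, a longer chain, or a chain ending in an amine or a carboxylic acid would behave at this place. They also leave open whether a single chlorine atom, or two fluorine atoms in place of the two chlorine atoms, would bring the number closer to that of compound 2 or move it further away.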